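Adding a Second Ring Methyl: From Compound 2 to Compound 3

This account rests on a few compounds, and the source may have more. Where it says the series, first, only, none or still open, it means among the compounds named here.

compound 1 `CC1=C(C)C(=O)c2nn(Cc3ccccc3)nc2C1=O` — 3.5 ug/mL
compound 2 `CC1=CC(=O)c2nn(C)nc2C1=O` — 2.5 ug/mL

In a functional assay on KB cells (Homo sapiens) for inhibition, read by colorimetric assay, with a stated time of 72 h (a lower number here means that less compound is needed, a higher number that more compound is needed for the effect), compound 2 gives 2.5 ug/mL, the lowest of the two numbers. Compound 1 gives 3.5 ug/mL in this assay, which lies within the scatter of that value. Compound 3 `CC1=C(C)C(=O)c2nn(C)nc2C1=O` differs from compound 2 by methyl in place of hydrogen on a double-bonded ring carbon, a methyl in place of hydrogen on a double-bonded ring carbon. Going by the values given here, no measured pair shows this change alone. Because compound 1, which carries the same two ring methyls, gives 3.5 ug/mL, no step beyond the scatter is expected. Compound 3 is expected to give 3 ug/mL, between 1.5 ug/mL and 6 ug/mL. That estimate means a step of a 1.2-fold higher number from compound 2 to compound 3 (0.08 log units; within the scatter).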

Compound 3, concentration for half-maximal effect: 3 ug/mL
The estimate for compound 3 equals the measured number at the digits printed, within the range that was stated.
By their numbers in this assay, from the lowest: compounds 2, 3 and 1 (each within the scatter of the next).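

In this assay, going by these compounds alone, the double-bonded ring carbon takes methyl in place of hydrogen with a 1.2-fold higher number from compound 2 to compound 3 (0.08 log units; within the scatter), the first direct reading of this change. On the saturated chain carbon bound to an aromatic nitrogen, hydrogen in place of phenyl gives a 1.2-fold lower number from compound 1 to compound 3 (0.07 log units; within the scatter), so that change also leaves the number within the scatter. No supporting measurement bears on these results.

From the compounds shown here alone, whether this ring carbon would tolerate an amine or a longer chain remains open. So does the effect of a carboxylic acid on the chain at the aromatic nitrogen.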